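This account rests on a few compounds, and the source may have more. Where it says the series, first, only, none or still open, it means among the compounds named here.

Measured so far: compound 1 `CCCN(CCC(F)(F)F)Cc1c(C(F)(F)F)nc2n(-c3c(C)cc(C)cc3C)c(Cl)cn12` gives 12 nM in an assay on cells for displacement of a labelled ligand from corticotropin-releasing factor receptor 1 (Homo sapiens), with a stated time of 100 min; a lower number here means a stronger inhibitor, a higher number a weaker inhibitor; compound 2 `CCCCN(C)Cc1c(C(F)(F)F)nc2n(-c3c(C)cc(C)cc3C)c(Cl)cn12` gives 310 nM in this assay.

Compound 1 stands lowest of the two numbers. For the measured compounds named here, the single measured step, a 26-fold higher number from compound 1 to compound 2 (1.41 log units; beyond the scatter), changes both groups on the amine nitrogen at once, so it shows only that this position answers strongly. Compound 3 `Cc1cc(C)c(-n2c(Cl)cn3c(CN(CCC(F)(F)F)Cc4cccc(F)c4)c(C(F)(F)F)nc23)c(C)c1` differs from compound 1 by 3-fluorophenyl in place of ethyl on a saturated chain carbon bound to an amine nitrogen. The trifluoropropyl group of compound 1 is kept, which argues against a loss as large as that step. A moderate weakening is therefore expected, a 2.9-fold higher number from compound 1 to compound 3 (0.46 log units; beyond the scatter). Compound 3 is expected at 35 nM, in the range 6 nM to 200 nM.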

Compound 3, inhibition constant: 49 nM
Compound 3: the middle estimate sits 1.4-fold (0.15 log units) below what was measured, within the range that was stated.
By their numbers in this assay, from the lowest: compound 1; then compound 3; then compound 2.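

With the trifluoropropyl group kept, replacing propyl with 3-fluorobenzyl on the amine nitrogen costs only a modest amount in this assay (a 4.1-fold higher number from compound 1 to compound 3 (0.61 log units; beyond the scatter)). This position therefore tolerates a group carrying a six-membered aromatic ring, with a smaller loss than the step that changes both amine groups (a 26-fold higher number from compound 1 to compound 2 (1.41 log units; beyond the scatter)). Nothing available explains this difference. The compounds shown leave open what the fluorine of the 3-fluorobenzyl group contributes. They also leave open whether a plain benzyl or a cyclopropylmethyl group here would match compound 1.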